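A few compounds are considered here, and "the series" means these few. Any claim that something is new, unique, unknown or untested is made for them only; others in the source may bear on it.

Measured compounds in an assay on cells for agonist activity at ecdysone receptor (Bombyx mori), read by a luciferase reporter, with a stated time of 24 h; a higher number here means that more compound is needed for the effect, a lower number that less compound is needed:

Compound 1, `CN(NC(=O)c1ccccc1)C(=O)c1ccccc1`, gives > 100000 nM, which is a limit of this assay rather than a number.
Compound 2, `CC(C)CN(NC(=O)c1ccccc1)C(=O)c1ccccc1`, gives 2880 nM.
Compound 3, `O=C(NN(C(=O)c1ccccc1)C1CCCCC1)c1ccccc1`, gives 891 nM.

Compound 3 stands lowest of the two numbers shown; its nearest neighbour is compound 2, and the step of a 3.2-fold lower number from compound 2 to compound 3 (0.51 log units; beyond the scatter) lies beyond the scatter. Compound 4, `O=C(NN(CC1CCCCC1)C(=O)c1ccccc1)c1ccccc1`, has not yet been measured. Its change from compound 3 is cyclohexylmethyl in place of cyclohexyl on an amide-type nitrogen. The measured steps that bear on this are the large one an at least 34-fold lower number from compound 1 to compound 2 (1.54 log units; beyond the scatter) and the modest one a 3.2-fold lower number from compound 2 to compound 3 (0.51 log units; beyond the scatter), both of which concern the group on this same amide-type nitrogen; the large step of an at least 110-fold lower number from compound 1 to compound 3 (2.05 log units; beyond the scatter) spans both. Moving from cyclohexyl to cyclohexylmethyl is a smaller change than either of those, so a step within the scatter, or at most a modest one in either direction, is expected. The expected step is a 1.1-fold higher number from compound 3 to compound 4 (0.05 log units; within the scatter). Compound 4 is therefore estimated at 1000 nM, with a range from 300 nM to 3500 nM.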

Compound 4, half-maximal effective concentration: 1700 nM
Estimate against measurement, compound 4: 1.7-fold (0.23 log units) below; measured number inside the range.
By their numbers in this assay, from the lowest: compounds 3, 4 and 2 (each within the scatter of the next, the first and the last beyond it). At a limit, above all of these: compound 1.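

On this amide-type nitrogen, the ring can be moved out from cyclohexyl to cyclohexylmethyl without a clear change, as a 1.9-fold higher number from compound 3 to compound 4 (0.28 log units; within the scatter) shows, and compound 4 also cannot be told apart from the isobutyl compound, with a 1.7-fold lower number from compound 2 to compound 4 (0.23 log units; within the scatter). The large gain over methyl therefore holds for a third bulkier saturated carbon group, with an at least 58-fold lower number from compound 1 to compound 4 (1.76 log units; beyond the scatter), so it does not depend on the ring sitting directly on the nitrogen. That step is a bound and not an exact size, since compound 1 stands at a limit rather than at a number: the limit of > 100000 nM in this assay, at which 1 of the 4 values shown sits.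

Every group shown on this nitrogen is a saturated carbon group, so it remains open whether a benzyl group, a longer chain or an amine would fit there as well. On these data alone, how far the group can grow before the number rises clearly also remains open.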